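The source may report more compounds than this note shows. Statements on the series, on what has been measured and on what is new or still open speak of the compounds shown alone.

Measured in an ADME assay on MT4 cells (Homo sapiens) for cytotoxicity; a higher number here means that more compound is tolerated, a lower number that less compound is tolerated:
- compound 1 `FC(F)(F)c1cccc(NC(=S)Nc2ccc(I)cc2)c1` gives 10000 nM
- compound 2 `FC(F)(F)c1cccc(NC(=S)Nc2ccc(Cl)cc2)c1` gives 6800 nM
- compound 3 `CC(=O)NC(=S)Nc1cccc(C(F)(F)F)c1` gives > 100000 nM

Compound 3 stands at > 100000 nM in this assay and this is a limit, not a number. The next compound is compound 4 `CSCCCNC(=S)Nc1cccc(C(F)(F)F)c1`, still unmeasured. The change is 3-(methylsulfanyl)propyl in place of acetyl on an amide-type nitrogen and reads in words as 3-(methylsulfanyl)propyl in place of acetyl on an amide-type nitrogen.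

For the measured compounds named here, no measured step makes this exact exchange. The nearest steps put acetyl in place of an aromatic group on the same nitrogen, and both are beyond the scatter: an at least 10-fold higher number from compound 1 to compound 3 (1.00 log units; beyond the scatter) and an at least 14-fold higher number from compound 2 to compound 3 (1.16 log units; beyond the scatter) are lower bounds on size. The halogen exchange is within the scatter (a 1.5-fold lower number from compound 1 to compound 2 (0.17 log units; within the scatter)).

Acetyl leaves here too, but the entering group has no ring, so a move to a lower number is expected, smaller than the drop implied by those two steps. The expected step is an at least 2.5-fold lower number from compound 3 to compound 4 (0.39 log units; beyond the scatter). This step remains uncertain because the value of compound 3 at one end of it is > 100000 nM as a limit. For compound 4 the estimated value is 40000 nM (expected range 12000 nM to 100000 nM).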

Compound 4, half-maximal cytotoxic concentration: 43000 nM
Compound 4: middle estimate off by 1.1-fold (0.03 log units), on the low side; measured number inside the range.
By their numbers in this assay, from the lowest: compounds 2 and 1 (each within the scatter of the next); then compound 4. At a limit, above all of these: compound 3.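

In this assay, a group with no ring on the amide-type nitrogen now gives a measured value, and that value sits apart from both aromatic compounds: a 6.3-fold higher number from compound 2 to compound 4 (0.80 log units; beyond the scatter) and a 4.3-fold higher number from compound 1 to compound 4 (0.63 log units; beyond the scatter). Having no ring on this nitrogen is therefore not enough to reach the level of compound 3, as an at least 2.3-fold lower number from compound 3 to compound 4 (0.36 log units; beyond the scatter) shows. Compound 3 is held at a limit and not a number, so this last step fixes only a lower bound on size: the limit of > 100000 nM in this assay, at which 1 of the 4 values shown sits.

From the compounds shown here alone, it remains open whether the sulfur of 3-(methylsulfanyl)propyl or the length of the chain sets the value of compound 4. A plain butyl chain, a longer chain or a terminal amine on the same nitrogen would separate these readings.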